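The source may report more compounds than this note shows. Statements on the series, on what has been measured and on what is new or still open speak of the compounds shown alone.

Measured so far:
- compound 1, `NC(=S)N/N=C/c1ccc2ccccc2n1`: 32700 nM
- compound 2, `Cc1ccc(NC(=O)N/N=C/c2ccc3ccccc3n2)cc1`: > 100000 nM
- compound 3, `Cc1csc2sc(/C=N/NC(N)=S)c(C)c12`: > 100000 nM

Three compounds have been run in a functional assay on SGC-7901 cells (Homo sapiens) for antiproliferative activity, read by sulforhodamine B assay, with a stated time of 72 h; a higher number here means a weaker inhibitor, a lower number a stronger inhibitor. Compound 1 is the only one of them for which this assay returns a number, 32700 nM. For compound 2 this assay reports only a limit, > 100000 nM. For compound 3 this assay likewise reports only a limit, > 100000 nM. Going by the values given here, compound 1 therefore stands alone as the one measured point; the limit of > 100000 nM in this assay, at which 2 of the 3 values shown sit, marks where the other two sit, so no step between measured compounds can be sized.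

Compound 4, `Fc1ccccc1NC(=S)N/N=C/c1ccc2ccccc2n1`, is the next compound to be measured in this assay. It differs from compound 1 in one place: 2-fluorophenyl in place of hydrogen on an amide-type nitrogen. The core of compound 1 and the thiocarbonyl group are kept.

Among the compounds with values here, with no measured step to lean on, the expectation for compound 4 rests on the structural change alone. The step from compound 1 to compound 4 is expected to run toward lower values, beyond the usual scatter, as a 6.5-fold lower number from compound 1 to compound 4 (0.82 log units; beyond the scatter). The estimate for compound 4 in this assay is 5000 nM, with a range from 800 nM to 30000 nM.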

Compound 4, half-maximal inhibitory concentration: > 100000 nM
Compound 4 gave a limit, no number (the forecaster's own chance of this, stated with the estimate: 15%); middle value at least 20-fold (1.30 log units) from the limit.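

In this assay compound 4 returns only a limit, > 100000 nM. Putting 2-fluorophenyl in place of hydrogen on the amide-type nitrogen, whose other neighbour is the thiocarbonyl carbon, gives an at least 3.0-fold higher number from compound 1 to compound 4 (0.48 log units; beyond the scatter), so this nitrogen is the one place in the series where a single change can be sized, and this change moves activity in the weaker direction, with the full size of the loss unknown. Compound 1, with its hydrogen on this nitrogen, remains the only compound shown with a number, and the measured set now sits largely at one ceiling: the limit of > 100000 nM in this assay, at which 3 of the 4 values shown sit.

On these data alone, it remains open whether the loss belongs to the aromatic ring itself or to its fluorine, which an unsubstituted phenyl on the same nitrogen would separate. As far as these compounds go, it is equally open whether this nitrogen accepts anything other than hydrogen, for instance a methyl, a short alkyl chain or a chain ending in an amine, while the core of compound 1 and the thiocarbonyl group are kept.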